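This account rests on a few compounds, and the source may have more. Where it says the series, first, only, none or still open, it means among the compounds named here.

In a functional assay on HeLa cells (Homo sapiens) for cytotoxicity, read by MTT assay (on this read-out lower numbers stand for stronger inhibition and higher numbers for weaker inhibition), compound 1 `CC(C)=CC[C@@H](OC[C@@H](C)O)C1=CC(=O)c2c(O)ccc(O)c2C1=O` gives 22500 nM and compound 2 `CC(=O)OCCC(=O)O[C@H](CC=C(C)C)C1=CC(=O)c2c(O)ccc(O)c2C1=O` gives 17300 nM. Within the data shown here, only these two numbers are known so far, and they lie within the scatter of each other, so compound 2 cannot be separated from its one measured neighbour. Among the measured compounds shown here, the single measured step, a 1.3-fold lower number from compound 1 to compound 2 (0.11 log units; within the scatter), also lies within the scatter. It exchanged one group for another on the same oxygen on a saturated carbon that changes again in compound 3 `COCCO[C@H](CC=C(C)C)C1=CC(=O)c2c(O)ccc(O)c2C1=O`. Here the change is 2-methoxyethyl in place of (2-acetoxyethyl)carbonyl on an oxygen on a saturated carbon, with 2-methoxyethyl in place of (2-acetoxyethyl)carbonyl. For the measured compounds named here, one step is thin evidence, and no measured compound yet carries 2-methoxyethyl. Even so, no shift beyond the scatter is expected in this assay. The expected change is a 1.0-fold higher number from compound 2 to compound 3 (0.02 log units; within the scatter), with no firm direction. For compound 3 the estimated value is 18000 nM, within an expected range of 7000 nM to 40000 nM.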

Compound 3, half-maximal inhibitory concentration: 62400 nM
The estimate for compound 3 lay 3.5-fold (0.54 log units) below the measured number; the measured number lies above the stated range.
By their numbers in this assay, from the lowest: compounds 2 and 1 (each within the scatter of the next); then compound 3.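

In this assay, the oxygen on a saturated carbon turns out not to be indifferent to what it carries: 2-methoxyethyl in place of (2-acetoxyethyl)carbonyl gives a 3.6-fold higher number from compound 2 to compound 3 (0.56 log units; beyond the scatter), and methoxymethyl in place of 1-hydroxyethyl on the saturated chain carbon gives a 2.8-fold higher number from compound 1 to compound 3 (0.44 log units; beyond the scatter), both modest steps. Compound 1 and compound 2 carry quite different groups here yet stay within the scatter of each other, so a change at this place does not always shift the number, and 2-methoxyethyl is the only group shown that moves it to a higher number. Nothing measured on these compounds accounts for this difference. The compounds shown leave open whether the terminal methyl ether alone sets compound 3 apart. They also leave open what an amine, a carboxylic acid or a longer alkyl chain on this oxygen would give.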